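A Fluoro Step Repeated on a Second Core

The source may hold more compounds than are shown below. What is called first, only, known or untested is meant among the compounds shown, and "the series" means these compounds.

Compound 1 `O=S(=O)(/C=C/c1ccccn1)c1ccccc1Cl` gives 618 nM in an assay on U2OS cells for activation of nuclear factor erythroid 2-related factor 2 (Homo sapiens), read by beta-arrestin recruitment, with a stated time of 6 h; a higher number here means that more compound is needed for the effect, a lower number that less compound is needed. Compound 2 `O=S(=O)(/C=C/c1ncccc1F)c1ccccc1Cl` carries fluoro in place of hydrogen on an aromatic carbon, and in this assay compound 2 gives 122 nM, which is a 5.1-fold lower number from compound 1 to compound 2 (0.70 log units; beyond the scatter). Compound 3 `O=S(=O)(/C=C/c1ccccn1)c1ccc(Cl)cc1` has the same atoms as compound 1, joined differently; the difference between the two cores is not broken down here. In this assay compound 3 gives 1730 nM, the highest number of the three measured compounds, with the gaps to compound 1 and compound 2 both beyond the usual scatter. Compound 4 `O=S(=O)(/C=C/c1ncccc1F)c1ccc(Cl)cc1` has not yet been measured. It stands to compound 3 as compound 2 stands to compound 1, carrying (fluoro in place of hydrogen on an aromatic carbon), the same change at the same place. The earlier change gave a 5.1-fold lower number from compound 1 to compound 2 (0.70 log units; beyond the scatter). A step of the same order is expected, a 4.3-fold lower number from compound 3 to compound 4 (0.64 log units; beyond the scatter), although this rests on that single earlier step and so the range is kept wide. Compound 4 is therefore estimated at 400 nM in this assay, expected to fall between 150 nM and 1200 nM.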

Compound 4, half-maximal effective concentration: 286 nM
Estimate against measurement, compound 4: 1.4-fold (0.15 log units) above; measured number inside the range.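

In this assay, fluoro in place of hydrogen on an aromatic carbon gives a 6.0-fold lower number from compound 3 to compound 4 (0.78 log units; beyond the scatter), and this step stands close to the one seen on the core of compound 1: the same change on two cores in this assay, a 5.1-fold lower number (0.70 log units; beyond the scatter) from compound 1 to compound 2 and a 6.0-fold lower number (0.78 log units; beyond the scatter) from compound 3 to compound 4, 1.2-fold (0.08 log units) apart, within the scatter of two such steps. Within this small set, the size of the step therefore carried over from one core to the other, and knowing it on the first core would have given a fair guide to the second. This does not show that the step would carry to cores beyond these two, which have the same atoms joined differently, and it rests on a single pair of steps in one assay, with no account of why the change acts as it does.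

The compounds shown leave open whether another group at the same place, such as methoxy, a nitrile or an amine, would give a step of this kind. They also leave open whether the fluoro step would hold if the chloro group gave way to trifluoromethyl or a carboxylic acid.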